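The compounds below may be only part of what the source reports. "The series", "measured", "known", "first", "only" and "open" are said of these compounds alone.

Compound 1 `O=C(Nc1cccc(-c2oc3cc(-c4ccc(F)cc4)ccc3c(=O)c2O)c1)c1ccccc1F`: 10100 nM
Compound 2 `COc1ccccc1C(=O)Nc1cccc(-c2oc3cc(-c4ccc(F)cc4)ccc3c(=O)c2O)c1`: 14500 nM

In a functional assay on HepG2 cells (Homo sapiens) for antiproliferative activity, read by CCK-8 assay, with a stated time of 72 h (a lower number here means a stronger inhibitor, a higher number a weaker inhibitor), compound 2 stands highest of the two numbers measured; its nearest neighbour is compound 1, with a 1.4-fold higher number from compound 1 to compound 2 (0.16 log units; within the scatter). Compound 3 `Cc1ccccc1C(=O)Nc1cccc(-c2oc3cc(-c4ccc(F)cc4)ccc3c(=O)c2O)c1` differs from compound 2 by methyl in place of methoxy on an aromatic carbon. Within the data shown here, the only measured step that bears on this change, fluoro to methoxy from compound 1 to compound 2, stayed within the scatter, and no other comparison is available. Exchanging methoxy for methyl is therefore expected to give no step beyond the scatter in this assay. Compound 3 is estimated at 12000 nM, range 5000 nM to 30000 nM, an expected step of a 1.2-fold lower number from compound 2 to compound 3 (0.08 log units; within the scatter).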

Compound 3, half-maximal inhibitory concentration: 19400 nM
Compound 3: middle estimate off by 1.6-fold (0.21 log units), on the low side, and the stated range covers the measured number.
By their numbers in this assay, from the lowest: compounds 1, 2 and 3 (each within the scatter of the next).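

In this assay, methyl on this aromatic carbon, ortho to a large group, gives a 1.3-fold higher number from compound 2 to compound 3 (0.13 log units; within the scatter) and a 1.9-fold higher number from compound 1 to compound 3 (0.28 log units; within the scatter). With methyl added, three groups have now been read at this place, and fluoro, methoxy and methyl all lie within the scatter of one another, even though methoxy to methyl removes one hydrogen-bond acceptor. No measured property is available to account for these readings. Still open, going by these compounds, is whether an amine or a carboxylic acid at this place would give a step beyond the scatter.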